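The compounds below may be only part of what the source reports. "The series", "measured", "known", "first", "only" and "open" are said of these compounds alone.

Compound 2 `COc1cc([C@](O)(CCN(C)C)[C@@H](c2cc3cc(Br)ccc3nc2OC)c2cccc(OC)c2F)cc(OC(C)C)n1` is the reference point. For the measured compounds named here, in an ADME assay on microsomes from liver (Homo sapiens) for metabolic stability (a higher number here means faster removal of the compound, a lower number slower removal), compound 2 gives 3.4 uL/min, the lowest of the three numbers measured so far. Its nearest neighbour is compound 1 `CCOc1cc([C@](O)(CCN(C)C)[C@H](c2cccc(C)c2)c2cc3cc(Br)ccc3nc2OC)cc(OC)n1`, which in this assay gives 4.4 uL/min, a gap within the scatter. The furthest is compound 3 `COc1cc([C@](O)(CCN(C)C)[C@@H](c2cc3cc(Br)ccc3nc2OC)c2ccnc(OC)c2OC)cc(OC(C)C)n1`, which in this assay gives 6.4 uL/min; the step of a 1.9-fold higher number from compound 2 to compound 3 (0.27 log units; within the scatter) also lies within the scatter.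

Compound 4 `COc1cccc([C@H](c2cc3cc(Br)ccc3nc2OC)[C@@](O)(CCN(C)C)c2cc(SC)nc(SC)c2)c1F` differs from compound 2 in this way: a group of 10 heavy atoms (7 carbon, 1 nitrogen, 2 sulfur; one six-membered aromatic ring with 1 hetero atom) in place of a group of 12 heavy atoms (9 carbon, 1 nitrogen, 2 oxygen; one six-membered aromatic ring with 1 hetero atom), on a saturated chain carbon bound to an oxygen on a saturated carbon and two saturated chain carbons. Going by the values given here, the only measured step, from compound 2 to compound 3, changes a group at a different place, the saturated chain carbon bound to an aromatic carbon and a saturated chain carbon, and it stayed within the scatter. Among the compounds with values here, no measured step touches the carbon bearing the oxygen where the change to compound 4 occurs, so there is no direct precedent for it. Within the data shown here, the three numbers sit close together throughout, and the one step available shows no movement beyond the scatter.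

On that basis compound 4 is expected to stay near compound 2, with a step of a 1.3-fold higher number from compound 2 to compound 4 (0.12 log units; within the scatter) in this assay. Compound 4 is therefore estimated at 4.5 uL/min, within a range from 2.2 uL/min to 9.5 uL/min.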

Compound 4, intrinsic clearance in a liver preparation (reported as CLH), per the amount of preparation that the assay uses: 3.4 uL/min
The estimate for compound 4 lay 1.3-fold (0.12 log units) above the measured number; measured number inside the range.
By their numbers in this assay, from the lowest: compounds 2, 4, 1 and 3 (each within the scatter of the next).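

For the compounds shown here, at the saturated chain carbon bound to an oxygen on a saturated carbon and two saturated chain carbons, which no earlier step had touched, this assay now has a first reading: putting the group of 10 heavy atoms, with its 2 sulfur, in place of the group of 12 heavy atoms, with its 2 oxygen, gives no change at the digits printed from compound 2 to compound 4 (within the scatter). Going by these compounds alone, this place therefore accepts this exchange with the number staying within the scatter, and the other place tested, the saturated chain carbon bound to an aromatic carbon and a saturated chain carbon, behaves alike in the one step read there, a 1.9-fold higher number from compound 2 to compound 3 (0.27 log units; within the scatter). Nothing at hand offers a measurement that would account for the number holding steady across this exchange.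

From the compounds shown here alone, a single step at this place cannot show how far it stays this flat, so whether an amine or a carboxylic acid on the six-membered aromatic ring would carry the number beyond the scatter remains open. Also open, going by these compounds, is whether changes at the two places would stay within the scatter when made together in one compound.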